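Trading the pyridine for a benzyl group

The source may hold more compounds than are shown below. What is called first, only, known or untested is meant among the compounds shown, and "the series" means these compounds.

Measured compounds:
compound 1, `CS(=O)(=O)NCCCN(c1nc(C(=O)NCc2ccc(F)cc2)c(O)c2ncccc12)S(C)(=O)=O`, > 20000 nM
compound 2, `N[C@H]1CC[C@H](Nc2c(C(=O)NCc3ccccn3)nc(Br)c3cccnc23)CC1`, 4000 nM

Of the compounds shown here, two have been tested in a functional assay on MDA-MB-435 cells (Homo sapiens) for cytotoxicity, read by MTT assay, with a stated time of 72 h; on this read-out higher numbers stand for weaker inhibition and lower numbers for stronger inhibition. Compound 1, `CS(=O)(=O)NCCCN(c1nc(C(=O)NCc2ccc(F)cc2)c(O)c2ncccc12)S(C)(=O)=O`, reaches only the limit of the assay, giving > 20000 nM. Going by the values given here, compound 2, `N[C@H]1CC[C@H](Nc2c(C(=O)NCc3ccccn3)nc(Br)c3cccnc23)CC1`, gives 4000 nM in this assay, and it is therefore the only compound here that returns a number. The value of compound 1, by contrast, sits at a limit of the assay, as noted in the limit of > 20000 nM in this assay, at which 1 of the 2 values shown sits. Among the compounds with values here, no pair of measured compounds differs in a single place, so no measured step is available to set the scale of what a small change does to the read-out.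

Compound 3, `N[C@H]1CC[C@H](Nc2c(C(=O)NCc3ccccc3)nc(Br)c3cccnc23)CC1`, is the compound still to be measured. It differs from compound 2 in one place: phenyl in place of pyridin-2-yl on a saturated chain carbon bound to an amide-type nitrogen. Within the data shown here, with no measured step to lean on, the expected change in this assay from compound 2 to compound 3 is estimated to lie within the usual scatter, no change at the digits printed from compound 2 to compound 3 (within the scatter). Compound 3 is therefore expected to give roughly 4000 nM in this assay, with a likely range from 1500 nM to 12000 nM.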

Compound 3, half-maximal inhibitory concentration: 7000 nM
Compound 3: middle estimate off by 1.8-fold (0.24 log units), on the low side; the measured number falls inside the stated range.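

Going by these compounds alone, this is the first step in the set that changes one place only, and it gives a scale for this position: phenyl in place of pyridin-2-yl, on a saturated chain carbon bound to an amide-type nitrogen, gives a 1.8-fold higher number from compound 2 to compound 3 (0.24 log units; within the scatter) in this assay and so does not separate the two compounds. At this place, then, the ring nitrogen of pyridin-2-yl, with the one hydrogen-bond acceptor counted for it, can be lost without the read-out leaving the usual scatter. Nothing measured here bears on why the two rings read alike.

As far as these compounds go, whether this tolerance extends to other groups at this place remains open, for instance a phenyl ring carrying a carboxylic acid or an aminomethyl group, or a longer chain between the amide nitrogen and the ring. This single step also says nothing about how the read-out answers a change elsewhere on the shared core, such as chlorine in place of the bromine.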